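Swapping ethoxy for trifluoromethyl on a shared quinoline-free core

The source may report more compounds than this note shows. Statements on the series, on what has been measured and on what is new or still open speak of the compounds shown alone.

Compound 1 `Cc1c(C(=O)Nc2c(F)cc(-c3cccc(F)c3)cc2F)nc2ccc(F)cc2c1C(=O)O` and compound 2 `CCOc1ccc2nc(C(=O)Nc3c(F)cc(-c4cccc(F)c4)cc3F)c(C)c(C(=O)O)c2c1` share one core and differ at a single aromatic carbon. In a functional assay on A-375 cells (Homo sapiens) for antiproliferative activity, read by MTT assay, with a stated time of 24 h, tested at 0.05 ug/mL (on this read-out lower numbers stand for a weaker effect and higher numbers for a stronger effect at the one concentration tested), compound 1 gives 0.37% and compound 2 gives 1.96%. Among the compounds with values here, the only measured step, a number 1.6 percentage points higher from compound 1 to compound 2 (within the scatter), keeps both compounds at almost no effect, so compound 2 stands with compound 1 as one of two weakly acting compounds whose numbers cannot be told apart.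

Compound 3 `Cc1c(C(=O)Nc2c(F)cc(-c3cccc(F)c3)cc2F)nc2ccc(C(F)(F)F)cc2c1C(=O)O` differs from compound 2 by trifluoromethyl in place of ethoxy on an aromatic carbon. Within the data shown here, no measured step involves trifluoromethyl, so the change from fluoro to ethoxy is the only guide, and it moved the read-out hardly at all. A step of no size beyond the scatter is therefore expected in this assay, as a number 0.5 percentage points lower from compound 2 to compound 3 (within the scatter). Compound 3 is estimated at 1.5%, with a range from 0% to 8%.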

Compound 3, a percentage reported as inhibition, at one concentration (the size of the read-out at that concentration, not a potency): 1.04%
Beside the measured number, compound 3's estimate is 0.5 percentage points above it, and the stated range covers the measured number.
By their numbers in this assay, from the lowest: compounds 1, 3 and 2 (each within the scatter of the next).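

Trifluoromethyl gives this aromatic carbon a third group, and in this assay the numbers stay together (a number 0.9 percentage points lower from compound 2 to compound 3 (within the scatter)) and (a number 0.7 percentage points higher from compound 1 to compound 3 (within the scatter)). Ethoxy has one hydrogen-bond acceptor and trifluoromethyl has none, yet that swap stays within the usual scatter, so fluoro, ethoxy and trifluoromethyl cannot be told apart at this position, all close to no effect at the one concentration tested. Nothing available explains this flat result.

On these data alone, it remains open whether a different kind of group on this carbon, such as an amine or a longer chain, would give a clearly larger number. As far as these compounds go, it is also open whether these three compounds would separate at a higher concentration or whether a change elsewhere on the shared core matters more.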